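The source may report more compounds than this note shows. Statements on the series, on what has been measured and on what is new or still open speak of the compounds shown alone.

Compound 1, `Cc1cccc(NC(=O)CSc2nnc(-c3ccoc3C)n2Cc2ccco2)c1`: 50.1 nM
Compound 2, `Cc1occc1-c1nnc(SCC(=O)Nc2ccc(F)cc2)n1Cc1ccco1`: 158 nM

Within the data shown here, in a functional assay on CHO cells for antagonist activity at Orexin receptor type 2 (Homo sapiens), read by FLIPR and calcium flux (on this read-out lower numbers stand for stronger inhibition and higher numbers for weaker inhibition), compound 2 holds the higher of the two numbers, and the only measured step, a 3.2-fold higher number from compound 1 to compound 2 (0.50 log units; beyond the scatter), separates it from compound 1. Compound 3, `Cc1occc1-c1nnc(SCC(=O)Nc2ccc(Cl)cc2)n1Cc1ccco1`, is the next compound, differing from compound 2 by chloro in place of fluoro on an aromatic carbon. Among the measured compounds shown here, the single measured step swapped one substituted phenyl ring for another, a 3-methylphenyl for a 4-fluorophenyl, so it speaks to the ring as a whole and not to an exchange of one halogen for another at the same carbon; no measured step bears directly on the change from compound 2 to compound 3. With nothing pointing either way, the expected step is a 1.4-fold lower number from compound 2 to compound 3 (0.16 log units; within the scatter), which lies within the scatter. For compound 3 the estimate in this assay is 110 nM, with a range from 40 nM to 300 nM.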

Compound 3, inhibition constant: 100 nM
Beside the measured number, compound 3's estimate is 1.1-fold (0.04 log units) above it; low and high end bracket the measured number.
By their numbers in this assay, from the lowest: compounds 1, 3 and 2 (each within the scatter of the next, the first and the last beyond it).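

In this assay, chloro in place of fluoro on the aromatic carbon para to a large group gives a 1.6-fold lower number from compound 2 to compound 3 (0.20 log units; within the scatter) and so does not separate these two halogens at this position. Among these compounds, this is the first exchange confined to that one carbon, whereas the earlier step replaced one substituted phenyl ring with another. The change from 3-methylphenyl to 4-chlorophenyl gives a 2.0-fold higher number from compound 1 to compound 3 (0.30 log units; within the scatter) and therefore also stays within the usual scatter, while the printed step from 3-methylphenyl to 4-fluorophenyl, a 3.2-fold higher number from compound 1 to compound 2 (0.50 log units; beyond the scatter) in size, lies beyond it.

On these data alone, whether an amine, a carboxylic acid or a methoxy group on that same carbon would shift the number beyond the scatter remains open. Nothing available explains these numbers.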